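The source may report more compounds than this note shows. Statements on the series, on what has been measured and on what is new or still open speak of the compounds shown alone.

Compound 1 `CCCCCCCNC[C@@H]1OC[C@H](N)[C@@H]1O`: > 128000 nM (a limit)
Compound 2 `CCCCCCCNC[C@@H]1OC[C@H](N)[C@H]1O`: > 128000 nM (a limit)
Compound 3 `CCCCCCCCCCNC[C@@H]1OC[C@H](N)[C@H]1O`: 42700 nM

The read-out throughout is a functional assay on MCF7 cells (Homo sapiens) for antiproliferative activity, read by MTT assay, with a stated time of 72 h; on this read-out higher numbers stand for weaker inhibition and lower numbers for stronger inhibition. Compound 1 stands at the limit of > 128000 nM in this assay, at which 2 of the 3 values shown sit. Compound 4 `CCCCCCCCCNC[C@@H]1OC[C@H](N)[C@@H]1O` keeps the core and configuration of compound 1, with one change: ethyl in place of hydrogen on a saturated chain carbon, seven bonds along the chain from an amine nitrogen. The configuration comparison gives a step that the two limits leave unreadable from compound 1 to compound 2, so its size cannot be carried over. The closest guide is an at least 2.9-fold lower number from compound 2 to compound 3 (0.47 log units; beyond the scatter), where propyl enters at the same place, on the other configuration. Compound 4 gains only ethyl, so a modest move to lower numbers is expected, and it may stay at the limit. The expected change is an at least 1.7-fold lower number from compound 1 to compound 4 (0.23 log units; that floor lies within the scatter). For compound 4 the estimate is 75000 nM, with an expected range of 30000 nM to 128000 nM.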

Compound 4, half-maximal inhibitory concentration: 12500 nM
Compound 4: the middle estimate sits 6.0-fold (0.78 log units) above what was measured; measured number outside the range, below it.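

In this assay, among the compounds shown here, ethyl at this place on the configuration of compound 1 gives an at least 10-fold lower number from compound 1 to compound 4 (1.01 log units; beyond the scatter), the first step on this configuration that can be read. Compound 1 gives > 128000 nM, which is a limit, so this step is a floor: the limit of > 128000 nM in this assay, at which 2 of the 4 values shown sit.

From the compounds shown here alone, the step between the two configurations cannot be read, and compound 3 and compound 4 differ in two places, so the effect of configuration on the longer chains stays open. Going by these compounds, whether a longer chain, or a chain ending in a carboxylic acid, lowers the number further also stays open.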